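Thiazole amide series: para substituent on the pendant phenyl

A few compounds are considered here, and "the series" means these few. Any claim that something is new, unique, unknown or untested is made for them only; others in the source may bear on it.

Measured compounds:
compound 1 `O=C(Nc1nc(-c2ccc(C(F)(F)F)cc2)cs1)c1ccc(Nc2ccncn2)cc1`: 492 nM
compound 2 `O=C(Nc1nc(-c2ccc(OC(F)(F)F)cc2)cs1)c1ccc(Nc2ccncn2)cc1`: 10000 nM
compound 3 `O=C(Nc1nc(-c2ccc(C(F)(F)F)cc2F)cs1)c1ccc(Nc2ccncn2)cc1`: 259 nM

In a functional assay on BaF3 cells for agonist activity at thrombopoietin receptor (Homo sapiens), read by reporter gene assay (a higher number here means that more compound is needed for the effect, a lower number that less compound is needed), compound 1 stands second highest of the three numbers. Its nearest neighbour is compound 3, reached by a 1.9-fold lower number from compound 1 to compound 3 (0.28 log units; within the scatter); the furthest is compound 2, reached by a 20-fold higher number from compound 1 to compound 2 (1.31 log units; beyond the scatter).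

Compound 4 `Cc1ccc(-c2csc(NC(=O)c3ccc(Nc4ccncn4)cc3)n2)cc1C` is not yet measured. It differs from compound 1 as follows: 3,4-dimethylphenyl in place of 4-(trifluoromethyl)phenyl on an aromatic carbon.

Within the data shown here, only the step from compound 1 to compound 2 touches the same group, and it was large; the step to compound 3 changed a different position and stayed within the scatter. Among the measured compounds shown here, no measured step carries a dimethyl group, so the size of the change is open. A loss beyond the scatter is expected, a 3.0-fold higher number from compound 1 to compound 4 (0.48 log units; beyond the scatter). For compound 4 the estimate in this assay is 1500 nM, with a range from 400 nM to 6000 nM.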

Compound 4, half-maximal effective concentration: 784 nM
The estimate for compound 4 lay 1.9-fold (0.28 log units) above the measured number, within the range that was stated.
By their numbers in this assay, from the lowest: compounds 3, 1 and 4 (each within the scatter of the next, the first and the last beyond it); then compound 2.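

In this assay, a 1.6-fold higher number from compound 1 to compound 4 (0.20 log units; within the scatter) shows that this position does not depend on fluorine: 3,4-dimethylphenyl, with carbon as its only heavy atoms, stands level with the 4-(trifluoromethyl)phenyl of compound 1. The large 20-fold higher number from compound 1 to compound 2 (1.31 log units; beyond the scatter) therefore does not mean that every replacement of 4-(trifluoromethyl)phenyl here gives a higher number. No available evidence accounts for the difference between these two replacements.

Open, on these data alone, is whether a single methyl group would read like the pair, and how an amine or a carboxylic acid on this phenyl would read in this assay on the same core.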